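Trimming the outer amine arm of a CXCR4 antagonist

The compounds below may be only part of what the source reports. "The series", "measured", "known", "first", "only" and "open" are said of these compounds alone.

In a functional assay on cells for antagonist activity at C-X-C chemokine receptor type 4 (Homo sapiens), read by fluorescence and calcium flux, with stated times of 25 min and 90 s (on this read-out lower numbers stand for stronger inhibition and higher numbers for weaker inhibition), compound 1 `c1cncc(CN(CCCCN(C[C@H]2Cc3ccccc3CN2)[C@H]2CCCc3cccnc32)Cc2cccnc2)c1` gives 471 nM, while compound 2 `c1ccc2c(c1)CN[C@@H](CN(CCCCNCC1CCCCC1)[C@H]1CCCc3cccnc31)C2` gives 158 nM, the lowest of the two numbers, with compound 1 sitting beyond the scatter above it. Compound 3 `CC(C)(CCN)CN(C[C@H]1Cc2ccccc2CN1)[C@H]1CCCc2cccnc21` carries a group of 6 heavy atoms (5 carbon, 1 nitrogen; no ring) in place of a group of 11 heavy atoms (10 carbon, 1 nitrogen; one six-membered non-aromatic ring of carbon only), on a saturated chain carbon bound to an amine nitrogen. Going by the values given here, no measured pair shows a step of this kind, so the size must be guessed. Compound 3 is expected to lose some of the inhibition of compound 2, a step of a 2.8-fold higher number from compound 2 to compound 3 (0.45 log units; beyond the scatter) in this assay, giving an estimated 450 nM with a range of 120 nM to 1700 nM.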

Compound 3, half-maximal inhibitory concentration: > 33300 nM
Compound 3: a limit, no number; the forecaster's own chance of this, stated with the estimate: 5%; at least 74-fold (1.86 log units) between middle value and limit.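

Cutting the 3-((cyclohexylmethyl)amino)propyl group back to the smaller group without a ring, on a saturated chain carbon bound to an amine nitrogen, gives an at least 210-fold higher number from compound 2 to compound 3 (2.32 log units; beyond the scatter) in this assay. The outer arm at this position is therefore far from a free variable: inhibition here depends heavily on what it carries. Compound 3 reaches only a limit of the assay, not a number, so the full size of the loss stays unknown: the limit of > 33300 nM in this assay, at which 1 of the 3 values shown sits.

From the compounds shown here alone, whether a cyclohexyl ring alone, a benzyl group or a longer chain ending in an amine would restore inhibition remains open.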